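The compounds below may be only part of what the source reports. "The series", "measured", "known", "first", "only" and "open" are said of these compounds alone.

Measured so far in a functional assay on HCT-15 cells (Homo sapiens) for inhibition, read by MTT assay, with a stated time of 72 h; a higher number here means a weaker inhibitor, a lower number a stronger inhibitor:
- compound 1, `COc1cc(Oc2cccc(Nc3ccccc3)c2)cc(OC)c1CNCc1ccc(F)cc1`, gives 3640 nM
- compound 2, `COc1cc(Oc2cccc(Nc3ccccc3)c2)cc(OC)c1CNCc1ccc(C)cc1`, gives 5400 nM

Within this pair compound 1 carries the lower of the two numbers, but the step from compound 1 to compound 2 is a 1.5-fold higher number from compound 1 to compound 2 (0.17 log units; within the scatter), so no order between them can be claimed. Compound 3, `COc1cc(Oc2cccc(Nc3ccccc3)c2)cc(OC)c1CCO`, is not yet measured. Relative to compound 1 it shows (hydroxymethyl in place of (4-fluorobenzyl)amino on a saturated chain carbon bound to an aromatic carbon). Within the data shown here, the only measured step, from compound 1 to compound 2, concerns a substituent on the aromatic ring of the group that leaves here and bears on the present change only loosely; it was a 1.5-fold higher number from compound 1 to compound 2 (0.17 log units; within the scatter). Among the measured compounds shown here, no measured step removes the (4-fluorobenzyl)amino group itself, so the expectation rests on the counted difference alone. A weaker inhibitor is expected for compound 3, with an estimated step of a 3.3-fold higher number from compound 1 to compound 3 (0.52 log units; beyond the scatter). For compound 3 the expected value in this assay is 12000 nM, estimated to lie between 4000 nM and 40000 nM.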

Compound 3, half-maximal inhibitory concentration: 12100 nM
For compound 3 the middle estimate is 1.0-fold (0.00 log units) below the measured one, within the range that was stated.
By their numbers in this assay, from the lowest: compounds 1 and 2 (each within the scatter of the next); then compound 3.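

In this assay, hydroxymethyl in place of (4-fluorobenzyl)amino gives a 3.3-fold higher number from compound 1 to compound 3 (0.52 log units; beyond the scatter), and hydroxymethyl in place of (4-methylbenzyl)amino gives a 2.2-fold higher number from compound 2 to compound 3 (0.35 log units; beyond the scatter). Unlike the change on the aromatic carbon, both steps lie beyond the scatter, so this place on a saturated chain carbon bound to an aromatic carbon does register a change in this assay, though only a modest one. Compound 3, with its aromatic ring and nitrogen gone from this group, still gives a finite value of 12100 nM, so neither is needed for a measurable reading.

The compounds shown do not separate the part played by the nitrogen from that of the aromatic ring, as both leave in the same change. A simple primary amine, a carboxylic acid or a longer chain at this place would test that further. No measurement on hand accounts for the size of these steps.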